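The compounds below may be only part of what the source reports. "The series", "measured", "known", "first", "only" and "open" are said of these compounds alone.

Measured so far in an ADME assay on cells (Macrophage) for cytotoxicity, read by MTT assay, with a stated time of 24 h; on this read-out higher numbers stand for lower toxicity in this test and lower numbers for higher toxicity in this test:

Compound 1, `COc1cccc(/C=C/C(=O)NNC(=O)c2ccc3c(c2)OCCO3)c1`: 398000 nM
Compound 2, `Cc1ccc(/C=C/C(=O)NNC(=O)c2ccc3c(c2)OCCO3)cc1`: 332000 nM
Compound 3, `COc1ccc(/C=C/C(=O)NNC(=O)c2ccc3c(c2)OCCO3)cc1`: 319000 nM

All three share one core and differ only in the substituent pattern of the cinnamoyl aryl ring. Compound 1 stands at the top of the three numbers, yet its separation from compound 2 is a 1.2-fold lower number from compound 1 to compound 2 (0.08 log units; within the scatter) and from compound 3 is a 1.2-fold lower number from compound 1 to compound 3 (0.10 log units; within the scatter), both within the scatter. Between compound 2 and compound 3 the step is a 1.0-fold lower number from compound 2 to compound 3 (0.02 log units; within the scatter), again within the scatter. Nothing in this set moves this assay.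

Compound 4, `O=C(/C=C/c1ccccc1)NNC(=O)c1ccc2c(c1)OCCO2`, is not yet measured. Relative to compound 1 the change is hydrogen in place of methoxy on an aromatic carbon; cut one bond further out it reads 3-methoxyphenyl to phenyl. The steps from compound 1 to compound 2 and to compound 3 are the ones that bear on it, as each also alters the aryl substitution, and each stayed within the scatter. A step beyond the scatter is therefore not expected: the estimate for compound 4 is 370000 nM, range 230000 nM to 600000 nM, meaning an expected step of a 1.1-fold lower number from compound 1 to compound 4 (0.03 log units; within the scatter).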

Compound 4, half-maximal cytotoxic concentration: 312000 nM
Beside the measured number, compound 4's estimate is 1.2-fold (0.07 log units) above it; measured number inside the range.
By their numbers in this assay, from the lowest: compounds 4, 3, 2 and 1 (each within the scatter of the next).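

Hydrogen in place of methoxy on this aromatic carbon takes the substituent away altogether, and this assay still does not respond (a 1.3-fold lower number from compound 1 to compound 4 (0.11 log units; within the scatter)). The ring without a substituent also stays level with the other two compounds that carry one (a 1.0-fold lower number from compound 3 to compound 4 (0.01 log units; within the scatter); a 1.1-fold lower number from compound 2 to compound 4 (0.03 log units; within the scatter)), so across these four compounds neither the kind of substituent nor its presence separates the numbers. No measurement bears on why this position is so flat in this test.

From the compounds shown here alone, whether an amine or a carboxylic acid on this aromatic carbon, or a longer chain in place of methoxy, would give a step beyond the scatter stays open. Going by these compounds, all four compounds keep the shared core unchanged, so its contribution to these numbers also stays open.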